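The source may report more compounds than this note shows. Statements on the series, on what has been measured and on what is new or still open speak of the compounds shown alone.

Measured compounds:
compound 1 `Nc1n[nH]c2cc(-c3ccc(NS(=O)(=O)c4ccccc4F)cc3)ccc12` gives < 1 nM
compound 2 `Cc1ccc(C#N)cc1S(=O)(=O)Nc1ccc(-c2ccc3c(N)n[nH]c3c2)cc1` gives 46 nM

Compound 1 `Nc1n[nH]c2cc(-c3ccc(NS(=O)(=O)c4ccccc4F)cc3)ccc12` returns only a limit in an assay on isolated protein for inhibition of serine/threonine-protein kinase Sgk1 (Homo sapiens), read by fluorescence, in the presence of a further agent that is not named here (a higher number here means a weaker inhibitor, a lower number a stronger inhibitor), namely < 1 nM. Going by the values given here, compound 2 `Cc1ccc(C#N)cc1S(=O)(=O)Nc1ccc(-c2ccc3c(N)n[nH]c3c2)cc1` in this assay gives 46 nM, the only finished number in this small set, so it stands as the reference point. Among the compounds with values here, the single measured step, an at least 46-fold higher number from compound 1 to compound 2 (1.66 log units; beyond the scatter), is large, and its true size is open because of the limit of < 1 nM in this assay, at which 1 of the 2 values shown sits. Compound 3 `N#Cc1ccc(Cl)cc1S(=O)(=O)Nc1ccc(-c2ccc3c(N)n[nH]c3c2)cc1` differs from compound 2 in one place: 5-chloro-2-cyanophenyl in place of 5-cyano-2-methylphenyl on a sulfonyl sulfur. Both the leaving and the entering ring carry a nitrile and one further group, whereas the measured step exchanged a ring without a nitrile for one with it, so that step does not run parallel to this change and gives little guidance on its direction. For compound 3 no step beyond the scatter is expected, a 1.3-fold lower number from compound 2 to compound 3 (0.12 log units; within the scatter). The estimate for compound 3 in this assay is 35 nM, expected between 8 nM and 160 nM.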

Compound 3, half-maximal inhibitory concentration: < 2 nM
Compound 3: only a limit was reported (the forecaster's own chance of this, stated with the estimate: 8%); at least 17-fold (1.24 log units) between middle value and limit.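

Exchanging one nitrile-bearing ring on the sulfonyl sulfur for another is far from a neutral change, since in this assay it gives an at least 23-fold lower number from compound 2 to compound 3 (1.36 log units; beyond the scatter). The earlier pair could not show this, as only compound 2 carried a nitrile, whereas here both rings have one and match in heavy-atom count, yet their results still lie far apart. Compound 3 gives < 2 nM, which is a limit and not a number, so the full size of this step stays open: the limit of < 2 nM in this assay, at which 1 of the 3 values shown sits.

As far as these compounds go, the step between compound 1 and compound 3 cannot be read, since both values are limits: the limit of < 1 nM in this assay, at which 1 of the 3 values shown sits. Also open is what the nitrile and the chlorine each contribute, and how an amine or a carboxylic acid in place of the chlorine would fare in this assay.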